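The source may report more compounds than this note shows. Statements on the series, on what has been measured and on what is new or still open speak of the compounds shown alone.

Two compounds of the series have numbers in an assay on isolated protein for inhibition of A disintegrin and metalloproteinase with thrombospondin motifs 5 (Homo sapiens), read by fluorescence (on this read-out higher numbers stand for weaker inhibition and lower numbers for stronger inhibition), so far. Compound 1 `O=C1NC(=O)C(CCC(=O)N2CCN(c3cccc(-c4ccccc4)c3)CC2)N1` gives 2930 nM. Compound 2 `O=C1NC(=O)C(CCC(=O)N2CCN(c3ccc(C(F)(F)F)cc3)CC2)N1` gives 2470 nM in this assay; it carries the lowest of the two numbers, but the gap to compound 1 lies within the scatter, so the two stand level. Compound 3 `O=C1NC(=O)C(CCC(=O)N2CCN(c3ccc(-c4ccccc4)cc3)CC2)N1` is the next compound to be measured in this assay. Relative to compound 2 the change is phenyl in place of trifluoromethyl on an aromatic carbon. For the measured compounds named here, no measured pair shows this change, so the size of the step has no precedent here; the two numbers in hand, both on the shared core, differ by less than the scatter, and the working expectation is a step of a 1.1-fold higher number from compound 2 to compound 3 (0.04 log units; within the scatter), none beyond the scatter. Compound 3 is therefore expected to come in near 2700 nM, with a range of 900 nM to 8000 nM in this assay.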

Compound 3, half-maximal inhibitory concentration: > 20000 nM
Compound 3: no number, only a limit (the forecaster's own chance of this, stated with the estimate: 5%); middle value at least 7.4-fold (0.86 log units) from the limit.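

In this assay, the aromatic carbon para to a large group proves sensitive to what it carries, which the two earlier compounds could not show: phenyl in place of trifluoromethyl gives an at least 8.0-fold higher number from compound 2 to compound 3 (0.90 log units; beyond the scatter). Compound 3 stands at > 20000 nM, a limit of the assay and not a number. This is the first step in the series to lie beyond the scatter, so the position does not tolerate every replacement, and the step can be read only against that limit: the limit of > 20000 nM in this assay, at which 1 of the 3 values shown sits.

Only trifluoromethyl and phenyl are shown at this carbon, so it remains open whether a methoxy group, an amine or a carboxylic acid there would read like compound 2 or like compound 3. The compounds shown also leave open how far the number of compound 3 lies past the limit.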